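A nitrobenzyl group replaces acetylphenyl on the triazole-bearing core

A few compounds are considered here, and "the series" means these few. Any claim that something is new, unique, unknown or untested is made for them only; others in the source may bear on it.

Compound 1 `CC1(C)CCc2c(ccc(C(=O)/C=C/c3ccc(OCc4cn(-c5ccc(Cl)cc5)nn4)cc3)c2O)O1` gives "not active" (no number reported)
Compound 2 `Cc1c(-n2cc(COc3ccc(/C=C/C(=O)c4ccc5c(c4O)CCC(C)(C)O5)cc3)nn2)cccc1[N+](=O)[O-]` gives "not active" (no number reported)
Compound 3 `CC(=O)c1ccc(-n2cc(COc3ccc(/C=C/C(=O)c4ccc5c(c4O)CCC(C)(C)O5)cc3)nn2)cc1` gives 149000 nM

All three compounds were tested in a functional assay on A549 cells (Homo sapiens) for antiproliferative activity, read by MTT assay; a higher number here means a weaker inhibitor, a lower number a stronger inhibitor. They share one core and differ in the group on an aromatic nitrogen of a five-membered aromatic ring with 3 nitrogen. Only compound 3 has a number, 149000 nM. Compound 1 and compound 2 were reported without one, so nothing can be said about how far they lie from compound 3.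

The next compound to be read is compound 4 `CC1(C)CCc2c(ccc(C(=O)/C=C/c3ccc(OCc4cn(Cc5ccc([N+](=O)[O-])cc5)nn4)cc3)c2O)O1`, which carries 4-nitrobenzyl in place of 4-acetylphenyl on an aromatic nitrogen. Going by the values given here, no step between measured compounds is available to size this change. Among the compounds with values here, the sole numerical anchor is compound 3 at 149000 nM, and a direction cannot be drawn from it. The expected change, a 1.5-fold lower number from compound 3 to compound 4 (0.17 log units; within the scatter), is therefore none beyond the usual scatter of such measurements. With two of the three measured compounds lacking a number, a report without a number is also a real possibility for this one. If a number is obtained, the estimate for compound 4 is 100000 nM, with an expected range from 30000 nM to 300000 nM.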

Compound 4, half-maximal inhibitory concentration: 69900 nM
Estimate against measurement, compound 4: 1.4-fold (0.16 log units) above; low and high end bracket the measured number.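

In this assay, going by these compounds alone, a 2.1-fold lower number from compound 3 to compound 4 (0.33 log units; beyond the scatter) gives the first step that can be read at this aromatic nitrogen of the shared core, and it shows that the group placed there can move the number beyond the usual scatter, although the step is modest and compound 4 still gives 69900 nM. The exchange of 4-acetylphenyl for 4-nitrobenzyl alters the group on the aromatic ring and adds a carbon between that ring and the ring nitrogen in one move, so this single step cannot show how much each part contributes. Nothing in the available evidence bears on why the number falls.

Compound 1 and compound 2 carry no number, so steps involving them cannot be read, and their reports do not show how they rank against compound 4. On these data alone, it remains open whether 4-nitrophenyl or 4-acetylbenzyl on the same nitrogen would separate the two parts of this change, and whether 4-aminobenzyl or a longer chain between the ring nitrogen and the aromatic ring would move the number further.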